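Propyl in place of isopropyl on a carbonyl carbon

The source may hold more compounds than are shown below. What is called first, only, known or untested is meant among the compounds shown, and "the series" means these compounds.

In a functional assay on B16 cells (Mus musculus) for inhibition (a higher number here means a weaker inhibitor, a lower number a stronger inhibitor), compound 1 `COc1cc(/C=C/C(=O)c2cccc(NC(=O)c3c(Cl)cccc3Cl)c2)ccc1O` gives 1.58 ug/mL and compound 2 `COc1cc(/C=C/C(=O)c2cccc(NC(=O)C(C)C)c2)ccc1O` gives 1.09 ug/mL. These two values lie within the scatter of each other, so compound 2 stands level with compound 1 and the pair cannot be ranked.

Compound 3 `CCCC(=O)Nc1cccc(C(=O)/C=C/c2ccc(O)c(OC)c2)c1` keeps the shared core and has propyl in place of isopropyl on a carbonyl carbon. The two structures have the same atoms, joined differently.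

Within the data shown here, only one measured step bears on this change: a 1.4-fold lower number from compound 1 to compound 2 (0.16 log units; within the scatter). It occurred at the same place, with isopropyl in place of 2,6-dichlorophenyl, and stayed within the scatter. Among the measured compounds shown here, the series holds no measured pair that compares propyl with isopropyl, so this evidence is indirect.

With compound 2 as the anchor at 1.09 ug/mL, no shift beyond the scatter is expected in this assay, and no direction can be favoured. The expected step is a 1.1-fold higher number from compound 2 to compound 3 (0.04 log units; within the scatter). Compound 3 is estimated at 1.2 ug/mL, with an expected range of 0.6 ug/mL to 2.4 ug/mL.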

Compound 3, half-maximal inhibitory concentration: 1.43 ug/mL
For compound 3 the middle estimate is 1.2-fold (0.08 log units) below the measured one, and the stated range covers the measured number.
By their numbers in this assay, from the lowest: compounds 2, 3 and 1 (each within the scatter of the next).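

In this assay the swap of isopropyl for propyl on the carbonyl carbon gives a 1.3-fold higher number from compound 2 to compound 3 (0.12 log units; within the scatter) and stays within the scatter, so this first direct comparison of the two chains at this position does not separate them. The step from 2,6-dichlorophenyl gives a 1.1-fold lower number from compound 1 to compound 3 (0.04 log units; within the scatter) and also stays within the scatter, which means that propyl, like isopropyl, stands level with the aromatic group and that compounds 1, 2 and 3 cannot be ranked by the group at this position. The result therefore extends the flat picture from a single indirect step to all three pairs, while no supporting measurement is available to account for it.

The compounds shown span only these three groups on the carbonyl carbon, so it remains open whether any group at this position can move the number beyond the scatter. A longer chain such as hexyl, a chain ending in an amine or a carboxylic acid in this place would test whether the level seen here holds beyond propyl, isopropyl and 2,6-dichlorophenyl.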